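Removing the methyl from a prenyloxy anilinopyrimidine

The compounds below may be only part of what the source reports. "The series", "measured", "known", "first", "only" and "open" are said of these compounds alone.

Measured compounds:
compound 1, `CC(C)=CCOc1cc(Nc2ncccn2)ccc1Cl`, 2500 nM
compound 2, `CC(C)=CCOc1cccc(Nc2nccs2)c1`, 23000 nM
compound 3, `CC(C)=CCOc1cc(Nc2ncccn2)ccc1C`, 78000 nM

The assay in question is a functional assay on MT2 cells (Homo sapiens) for cytotoxicity; a higher number here means that more compound is tolerated, a lower number that less compound is tolerated. Among the three measured compounds, compound 3 stands at the highest number: compound 2 lies nearest, with a lower value, and compound 1 lies furthest, with a much lower value. Among the compounds with values here, the single measured step, a 31-fold higher number from compound 1 to compound 3 (1.49 log units; beyond the scatter), shows that changing the substituent at the carbon ortho to the (3-methylbut-2-en-1-yl)oxy group can move the read-out strongly.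

Compound 4, `CC(C)=CCOc1cccc(Nc2ncccn2)c1`, is not yet measured. It differs from compound 3 by hydrogen in place of methyl on an aromatic carbon. Within the data shown here, no measured pair reproduces this exact change. Compound 2 also carries hydrogen rather than methyl at that carbon, but it differs from compound 4 elsewhere. The value of compound 2, 23000 nM, is therefore only a loose guide. Given that compound 2 sits below compound 3 and that the one measured step at this carbon was large, a step downward of moderate size is expected for a 2.2-fold lower number from compound 3 to compound 4 (0.35 log units; beyond the scatter). Compound 4 is therefore estimated at 35000 nM, within a range from 12000 nM to 100000 nM.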

Compound 4, half-maximal cytotoxic concentration: > 100000 nM
Compound 4: no number, only a limit; the forecaster's own chance of this, stated with the estimate: 10%; middle value at least 2.8-fold (0.45 log units) away from the limit.
By their numbers in this assay, from the lowest: compound 1; then compound 2; then compound 3. At a limit, above all of these: compound 4.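

In this assay compound 4 gives > 100000 nM as a limit of the assay and not as a number, as recorded here: the limit of > 100000 nM in this assay, at which 1 of the 4 values shown sits. Hydrogen in place of methyl therefore reads only as an at least 1.2-fold higher number from compound 3 to compound 4 (0.10 log units; that floor lies within the scatter) and no more, so neither the true size of this change nor a direction beyond the scatter can be claimed at this carbon. Chloro now stands apart at this position, with an at least 40-fold higher number from compound 1 to compound 4 (1.60 log units; beyond the scatter) for its replacement by hydrogen, and the group on the nitrogen also counts, with an at least 4.3-fold higher number from compound 2 to compound 4 (0.63 log units; beyond the scatter) when the carbon carries hydrogen in both compounds.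

From the compounds shown here alone, the true value of compound 4 remains open, so the order of compound 3 and compound 4 stays unsettled. Going by these compounds, how a fluoro, a methoxy or an amine at this carbon would read also remains open.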